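The source may hold more compounds than are shown below. What is called first, only, known or untested is meant among the compounds shown, and "the series" means these compounds.

Measured so far: compound 1 `CC1CCN(c2c(S(=O)(=O)c3ccccc3)cnc3cc(F)ccc23)CC1` with 87%; compound 2 `COc1cccc(S(=O)(=O)c2cnc3cc(F)ccc3c2N2CCC(C)CC2)c1` with 90%; compound 3 `Cc1ccc2ncc(S(=O)(=O)c3ccccc3)c(N3CCC(C)CC3)c2c1` with 67%.

In an assay on isolated protein for displacement of a labelled ligand from metabotropic glutamate receptor 5 (Homo sapiens), with a stated time of 60 min, tested at 1 uM (on this read-out higher numbers stand for more inhibition at the one concentration tested (going by the name of the read-out) and lower numbers for less inhibition), compound 1 gives 87% and compound 2 gives 90%. The step of a number 3 percentage points higher from compound 1 to compound 2 (within the scatter) goes with the change (methoxy in place of hydrogen on an aromatic carbon). Compound 3 gives 67% in this assay, the lowest of the three numbers; the difference between the core of compound 3 and the core of compound 1 is not broken down here.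

Compound 4 `COc1cccc(S(=O)(=O)c2cnc3ccc(C)cc3c2N2CCC(C)CC2)c1` is not yet measured. It differs from compound 3 by methoxy in place of hydrogen on an aromatic carbon, the same change as from compound 1 to compound 2. Because a number 3 percentage points higher from compound 1 to compound 2 (within the scatter) lay within the scatter, only a small step is expected here as well, a number 3 percentage points higher from compound 3 to compound 4 (within the scatter). Compound 4 is therefore estimated at 70% in this assay, with a likely range from 55% to 85%.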

Compound 4, a percentage reported as inhibition, at one concentration (the size of the read-out at that concentration, not a potency): 96%
Estimate against measurement, compound 4: 26 percentage points below, and the stated range ends below it.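

In this assay, methoxy in place of hydrogen on an aromatic carbon gives a number 29 percentage points higher from compound 3 to compound 4 (beyond the scatter), and the size of this step does not carry from one core to the other: the same change on two cores in this assay, a number 3 percentage points higher (within the scatter) from compound 1 to compound 2 and a number 29 percentage points higher (beyond the scatter) from compound 3 to compound 4, 26 percentage points apart, beyond the scatter of two such steps

A step measured on one core therefore gives no reliable size for the same change on another core in this series. Two pairs do not show which difference between the cores goes with the gap, and a percentage at one concentration is not a potency.

Still open, as far as these compounds go, is how an amine, a carboxylic acid or a longer chain would read in place of methoxy on the same aromatic carbon. Also open, from the compounds shown here alone, is whether either step size would recur on a third core.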